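The source may hold more compounds than are shown below. What is called first, only, known or untested is meant among the compounds shown, and "the series" means these compounds.

Compound 1 `COc1cc(-c2cc(/C=C/C(=O)c3ccc(N)cc3)[nH]n2)cc(OC)c1OC`: 95%
Compound 2 `COc1ccc(-c2cc(/C=C/C(=O)c3cc(OC)c(OC)c(OC)c3)[nH]n2)cc1OC`: 95%
Compound 3 `COc1ccc(-c2cc(/C=C/C(=O)c3ccc(N)cc3)[nH]n2)cc1`: 103%

In a functional assay on ACHN cells (Homo sapiens) for cytotoxicity, read by sulforhodamine B assay, with a stated time of 48 h, tested at 0.01 uM (a lower number here means a stronger effect, a higher number a weaker effect of the compound at the concentration tested), compound 1 gives 95%. It stands level with compound 2 at the digits shown, and the two together hold the lowest of the three numbers. Compound 3 gives a somewhat higher reading, but the gap to compound 1 lies within the scatter of this assay, so no order among the three measured compounds can be drawn from these numbers; all three sit close to one another.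

Compound 4 `COc1cc(-c2cc(/C=C/C(=O)c3ccc(F)c(F)c3)[nH]n2)cc(OC)c1OC` is the compound to be measured. Relative to compound 1 the change is 3,4-difluorophenyl in place of 4-aminophenyl on a carbonyl carbon. For the measured compounds named here, no step between two measured compounds is available here that could guide the size of such an exchange. Since the three measured values themselves do not separate beyond the scatter, the expectation for compound 4 is a step of no size beyond the scatter, estimated as a number 1 percentage points lower from compound 1 to compound 4 (within the scatter). For compound 4 the value in this assay is thus estimated at 94%, with a range from 78% to 107%.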

Compound 4, a percentage reported as activity, at one concentration (the size of the read-out at that concentration, not a potency): 102%
Compound 4: the middle estimate sits 8 percentage points below what was measured; the range from low to high includes it.
By their numbers in this assay, from the lowest: compounds 1, 2, 4 and 3 (each within the scatter of the next).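

In this assay, for the compounds shown here, the exchange of 4-aminophenyl for 3,4-difluorophenyl on the carbonyl carbon gives a number 7 percentage points higher from compound 1 to compound 4 (within the scatter) and is the first step that can be read at this position. It shows that this position accepts a group with 0 hydrogen-bond donors and 0 hydrogen-bond acceptors in place of one with 1 of each, without a step that stands out from the scatter. Nothing measured here explains this outcome.

Going by these compounds, whether any other group on this carbonyl carbon, such as a carboxylic acid, a morpholine ring or a longer alkyl chain, would move the reading beyond the scatter stays open. So does whether the two groups compared here would separate under other test conditions.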